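Dienone series: swapping the hydroxyphenyl arm of compound 1

The compounds below may be only part of what the source reports. "The series", "measured", "known", "first", "only" and "open" are said of these compounds alone.

Working notes on a small set tested in an assay on isolated protein for inhibition of Alpha glucosidase (Homo sapiens), with stated times of 5 min and 15 min, tested at 50 uM; a lower number here means less inhibition, a higher number more inhibition at the concentration tested (going by the name of the read-out). Within the data shown here, compound 1 `O=C1/C(=C/c2ccccc2)CCC/C1=C\c1ccc(O)cc1` gives 53% in this assay and stands second highest of the three numbers so far. Compound 3 `O=C(/C=C(O)/C=C/c1ccc(O)c(O)c1)c1cc(Cl)ccc1O` gives 85.6% in this assay, a number beyond the scatter above that of compound 1. Compound 2 `COc1cc(/C=C2\CCC/C(=C\c3ccccc3)C2=O)cc(OC)c1OC` gives 16.3% in this assay, a number beyond the scatter below that of compound 1; it carries no hydrogen-bond donor, where compound 1 carries one.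

Compound 4 `O=C1/C(=C/c2ccccc2)CCC/C1=C\c1ccccc1Br` has not yet been measured. It differs from compound 1 in one place: 2-bromophenyl in place of 4-hydroxyphenyl on a double-bonded chain carbon bound to a double-bonded ring carbon. The change removes the single hydrogen-bond donor and the single hydrogen-bond acceptor of the leaving group and brings in a bromine.

On the numbers in hand, the donor-free compound 2 sits well below compound 1, so a fall beyond the scatter is the expectation, rather than no change. The step from compound 1 to compound 4 is expected to be a number 23 percentage points lower from compound 1 to compound 4 (beyond the scatter) in this assay. For compound 4 the estimate in this assay is 30%, with a range from 10% to 55%; the range is wide because only compound 2 with 16.3% speaks to a donor-free arm, and it is not a single-place neighbour of compound 1.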

Compound 4, a percentage reported as inhibition, at one concentration (the size of the read-out at that concentration, not a potency): 46.8%
For compound 4 the middle estimate is 16.8 percentage points below the measured one; the range from low to high includes it.
By their numbers in this assay, from the lowest: compound 2; then compounds 4 and 1 (each within the scatter of the next); then compound 3.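

In this assay, 2-bromophenyl in place of 4-hydroxyphenyl on a double-bonded chain carbon bound to a double-bonded ring carbon gives a step of a number 6.2 percentage points lower from compound 1 to compound 4 (within the scatter). Among these compounds, this is the first single-place step, and it shows that inhibition at the concentration tested can be retained at this position by an arm with no hydrogen-bond donor or acceptor, so the hydroxyl of compound 1 is not required for a read-out of this size. The measurements in hand offer no independent information that would explain this outcome.

The change replaces the hydroxyl with a bromine and also alters the substitution on the phenyl ring, so this single step cannot separate the contribution of the atom from that of its location. On these data alone, it also remains open whether an unsubstituted phenyl, or a phenyl carrying an amine or a carboxylic acid, at this place would give a similar read-out in this assay, and a percentage at one concentration cannot show whether compound 1 and compound 4 match in potency.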